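The source may report more compounds than this note shows. Statements on the series, on what has been measured and on what is new or still open speak of the compounds shown alone.

Measured in a functional assay on Jurkat cells (Homo sapiens) for antiproliferative activity, read by MTT assay; a lower number here means a stronger inhibitor, a higher number a weaker inhibitor:
- compound 1 `COc1cc2c(cc1OC)C(=O)/C(=C/c1cccc(C)c1)CC2`: 17000 nM
- compound 2 `COc1cc2c(cc1OC)C(=O)/C(=C/c1ccc(N)cc1)CC2`: 40000 nM

Compound 2, at 40000 nM, has the higher of the two numbers and is the weaker inhibitor of this pair. Compound 3 `COc1cc2c(cc1OC)C(=O)/C(=C/c1cc(Cl)cc(Cl)c1)CC2` keeps the core of compound 2 but differs from it by 3,5-dichlorophenyl in place of 4-aminophenyl on a double-bonded chain carbon bound to a double-bonded ring carbon. In words, it has 3,5-dichlorophenyl in place of 4-aminophenyl on a double-bonded chain carbon bound to a double-bonded ring carbon.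

Among the compounds with values here, only one measured step bears on this change. It is a 2.4-fold higher number from compound 1 to compound 2 (0.37 log units; beyond the scatter), made at the same place, and it lies beyond the scatter but is modest. Read in reverse, it shows that compound 1, which has no 4-aminophenyl, gives the lower number, 17000 nM. Within the data shown here, no measured compound yet carries chlorine, so this single step is thin evidence. A modest step towards a lower number is therefore expected in this assay, of about the same size. The estimated change is a 2.4-fold lower number from compound 2 to compound 3 (0.37 log units; beyond the scatter). For compound 3 the estimated value is 17000 nM, with an expected range from 6000 nM to 45000 nM.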

Compound 3, half-maximal inhibitory concentration: 7000 nM
Estimate against measurement, compound 3: 2.4-fold (0.39 log units) above; the range from low to high includes it.
By their numbers in this assay, from the lowest: compound 3; then compound 1; then compound 2.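

In this assay, the place on a double-bonded chain carbon bound to a double-bonded ring carbon now carries three different aryl groups on the shared core, and the numbers there spread further than the first pair showed. Replacing 4-aminophenyl with 3,5-dichlorophenyl gives the largest step seen so far at this place, a 5.7-fold lower number from compound 2 to compound 3 (0.76 log units; beyond the scatter), while replacing 3-methylphenyl with the same group still gives a 2.4-fold lower number from compound 1 to compound 3 (0.39 log units; beyond the scatter). Compound 3 is therefore the strongest inhibitor of the three, so the number of compound 1 did not mark the lower end at this place, and no measurement shown here explains this order.

The groups compared differ in both their atoms and their printed positions, so the compounds shown cannot separate what the chlorine atoms contribute from where they sit. Going by these compounds, it remains open how a plain phenyl group, a phenyl group with a single chlorine, or one with bromine or fluorine in place of chlorine would compare with 3,5-dichlorophenyl.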